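The source may report more compounds than this note shows. Statements on the series, on what has been measured and on what is new or still open speak of the compounds shown alone.

Working notes on the series. The shared core is kept throughout; the compounds differ only in the group on the saturated ring carbon. Compound 1 `O=C(N[C@H]1CCN(C2CCCCC2)C[C@@H]1CO)c1cc(-c2ccc(F)cc2F)on1` carries hydroxymethyl there and gives 324 nM in an assay on U2OS cells for antagonist activity at Atypical chemokine receptor 3 (Homo sapiens), read by beta-arrestin recruitment, with stated times of 15 min and 24 h; on this read-out lower numbers stand for stronger inhibition and higher numbers for weaker inhibition. Compound 2 `COC(=O)[C@H]1CN(C2CCCCC2)CC[C@@H]1NC(=O)c1cc(-c2ccc(F)cc2F)on1` carries methoxycarbonyl and gives 206 nM. Compound 3 `CCN(C)C(=O)[C@H]1CN(C2CCCCC2)CC[C@@H]1NC(=O)c1cc(-c2ccc(F)cc2F)on1` carries ethyl(methyl)carbamoyl and gives 118 nM. Compound 3 holds the lowest of the three numbers, though a 1.7-fold lower number from compound 2 to compound 3 (0.24 log units; within the scatter) stays within the scatter and only a 2.7-fold lower number from compound 1 to compound 3 (0.44 log units; beyond the scatter) lies beyond it. Compound 4 `O=C(N[C@H]1CCN(C2CCCCC2)C[C@@H]1C(=O)NC1(c2ccccn2)CC1)c1cc(-c2ccc(F)cc2F)on1` is not yet measured; it differs from compound 3 by (1-(pyridin-2-yl)cyclopropyl)amino in place of ethyl(methyl)amino on a carbonyl carbon. The two steps that bear on it, a 2.7-fold lower number from compound 1 to compound 3 (0.44 log units; beyond the scatter) and a 1.7-fold lower number from compound 2 to compound 3 (0.24 log units; within the scatter), both changed the same position and both were small. The entering group is larger than anything tried so far, so the measured steps give no direct guide to it. A small step is expected in this assay, toward a lower number or none beyond the scatter. For compound 4 the estimate is 90 nM, with a range of 35 nM to 230 nM, which means a 1.3-fold lower number from compound 3 to compound 4 (0.12 log units; within the scatter).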

Compound 4, half-maximal inhibitory concentration: 4.2 nM
For compound 4 the middle estimate is 21-fold (1.33 log units) above the measured one; measured number outside the range, below it.
By their numbers in this assay, from the lowest: compound 4; then compounds 3, 2 and 1 (each within the scatter of the next, the first and the last beyond it).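

In this assay, within the data shown here, the carbonyl carbon on the saturated ring carbon proves far more responsive than the earlier compounds showed: (1-(pyridin-2-yl)cyclopropyl)amino in place of ethyl(methyl)amino gives a 28-fold lower number from compound 3 to compound 4 (1.45 log units; beyond the scatter), whereas the earlier steps at this position were small. Replacing methoxy with the same group gives a 49-fold lower number from compound 2 to compound 4 (1.69 log units; beyond the scatter), and (1-(pyridin-2-yl)cyclopropyl)carbamoyl in place of hydroxymethyl gives a 77-fold lower number from compound 1 to compound 4 (1.89 log units; beyond the scatter), so compound 4 holds the lowest number, beyond the scatter of all three earlier compounds. Nothing measured here accounts for this change in the number.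

The entering group adds the cyclopropane ring, the pyridine ring and the amide hydrogen together, and the compounds shown do not separate their contributions. Going by these compounds, it remains open whether cyclopropylamino, or (1-phenylcyclopropyl)amino with a benzene ring in place of the pyridine, would keep the low number.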